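The compounds below may be only part of what the source reports. "The series", "measured", "known", "first", "only" and "open" are said of these compounds alone.

In an ADME assay on HEK293 cells (Homo sapiens) for cytotoxicity, read by MTT assay, with a stated time of 48 h (on this read-out higher numbers stand for weaker inhibition and lower numbers for stronger inhibition), compound 1 `CN(c1ccc(NC(=O)c2cc(C(F)(F)F)cc(C(F)(F)F)c2)cc1OCc1ccccc1C(F)(F)F)S(C)(=O)=O` reaches only the limit of the measurement, giving > 500000 nM. Compound 2 `Cc1ccc(C(F)(F)F)cc1COc1cc(NC(=O)c2cc(C(F)(F)F)cc(C(F)(F)F)c2)ccc1N(C)S(C)(=O)=O` likewise stops at the limit, with > 500000 nM. Compound 3 `CCCCCCOc1cc(NC(=O)c2cc(C(F)(F)F)cc(C(F)(F)F)c2)ccc1N(C)S(C)(=O)=O` also sits at the limit, at > 500000 nM. Because all three share (the limit of > 500000 nM in this assay, at which 3 of the 3 values shown sit), the steps a step that the two limits leave unreadable from compound 1 to compound 2, a step that the two limits leave unreadable from compound 1 to compound 3 and a step that the two limits leave unreadable from compound 2 to compound 3 cannot be sized. Compound 4 `CN(c1ccc(NC(=O)c2cc(C(F)(F)F)cc(C(F)(F)F)c2)cc1OCc1ccccc1C(F)(F)F)S(=O)(=O)Cc1ccccc1` differs from compound 1 by phenyl in place of hydrogen on a saturated chain carbon bound to a sulfonyl sulfur. Among the compounds with values here, none of the measured steps touches this place, and all of them are unreadable, so they give no size for the change to be expected in this assay. Compound 4 is therefore expected to remain at the limit as well, with an estimate of 500000 nM and a range from 200000 nM to 2000000 nM, which means an expected step of a number no higher from compound 1 to compound 4 (the limit leaves the size open).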

Compound 4, half-maximal inhibitory concentration: > 500000 nM
Compound 4 was reported as a limit (the forecaster's own chance of this, stated with the estimate: 85%); the middle value lies on the limit itself.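

The step from compound 1 to compound 4 cannot be read, because both compounds stand at the same limit, not at a number: the limit of > 500000 nM in this assay, at which 4 of the 4 values shown sit.

In this assay the compounds shown leave open how far apart these four really lie, and which change, if any, would move the read-out.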